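The source may report more compounds than this note shows. Statements on the series, on what has been measured and on what is new or still open speak of the compounds shown alone.

In a functional assay on DU-145 cells (Homo sapiens) for cytotoxicity, read by resazurin assay, with a stated time of 72 h (on this read-out higher numbers stand for weaker inhibition and lower numbers for stronger inhibition), the measured compounds stand as follows:

Compound 1 `Clc1nss/c1=N\c1ccc(OCc2ccccc2)cc1` gives 45000 nM.
Compound 2 `Clc1nss/c1=N\c1ccc(Oc2ccccc2)cc1` gives only a limit, > 100000 nM.
Compound 3 `CCCCOc1ccc(/N=c2\ssnc2Cl)cc1` gives 52000 nM.

Compound 3 thus holds one of two actual numbers, and the other, from compound 1, sits close to it: a 1.2-fold higher number from compound 1 to compound 3 (0.06 log units; within the scatter). The comparison with compound 2 is an at least 1.9-fold lower number from compound 2 to compound 3 (0.28 log units; that floor lies within the scatter), and compound 2 itself is only a limit (the limit of > 100000 nM in this assay, at which 1 of the 3 values shown sits).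

Compound 4 `CSc1ccc(/N=c2\ssnc2Cl)cc1` differs from compound 3 in one place: methylsulfanyl in place of butoxy on an aromatic carbon. Within the data shown here, no measured step swaps the oxygen-linked group for a sulfur-linked one, so the steps at hand bear only loosely. Those steps that changed the group on the oxygen were an at least 2.2-fold higher number from compound 1 to compound 2 (0.34 log units; beyond the scatter) and a 1.2-fold higher number from compound 1 to compound 3 (0.06 log units; within the scatter), one beyond the scatter and one within it. On that basis no step beyond the scatter is expected in this assay for compound 4, with a slight lean toward a higher number. The expected step is a 1.3-fold higher number from compound 3 to compound 4 (0.10 log units; within the scatter). Compound 4 is therefore estimated at 65000 nM, with a range from 25000 nM to 160000 nM.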

Compound 4, half-maximal inhibitory concentration: 14000 nM
For compound 4 the middle estimate is 4.6-fold (0.67 log units) above the measured one; measured number outside the range, below it.
By their numbers in this assay, from the lowest: compound 4; then compounds 1 and 3 (each within the scatter of the next). At a limit, above all of these: compound 2.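

Among these compounds, this is the first change at this aromatic carbon that replaces the oxygen link itself, as all the earlier compounds keep an oxygen there, and it gives a 3.7-fold lower number from compound 3 to compound 4 (0.57 log units; beyond the scatter) in this assay, which means stronger inhibition. The exchange of butoxy for methylsulfanyl thus shows that a smaller group with a sulfur link can go with a real gain on the read-out, even though it has 2 heavy atoms where butoxy has 5. Nothing measured here accounts for this gain.

The exchange alters the linking atom and the chain together, so the compounds shown leave open which of the two carries the step. A methoxy group or a butylsulfanyl group on this carbon would separate them, and an amine there would test a third kind of link.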